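Chain extension in a tris(hydroxymethyl)aminoalkyl aryl series

The source may report more compounds than this note shows. Statements on the series, on what has been measured and on what is new or still open speak of the compounds shown alone.

Measured compounds:
compound 1 `CCCCCCCCCCc1ccc(C(N)(CO)CO)cc1`, 0.3 mg/kg
compound 2 `CCCCCCCc1ccc(CCC(N)(CO)CO)cc1`, 0.1 mg/kg
compound 3 `CCCCCCCCCc1ccc(CCC(N)(CO)CO)cc1`, 0.03 mg/kg

In a functional assay on the whole organism with Rattus norvegicus as the target (a lower number here means that less compound is needed, a higher number that more compound is needed for the effect), compound 3 gives 0.03 mg/kg, the lowest number of the three. For the measured compounds named here, the nearest is compound 2 with 0.1 mg/kg; compound 1 gives 0.3 mg/kg, though compound 1 differs from compound 3 at more than one place and no single step links them.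

Compound 4 `CCCCCCCCCCc1ccc(CCC(N)(CO)CO)cc1` is the next member. It differs from compound 3 by methyl in place of hydrogen on a saturated chain carbon, nine bonds along the chain from an aromatic carbon. Going by the values given here, the one step that bears on it is a 3.3-fold lower number from compound 2 to compound 3 (0.52 log units; beyond the scatter), which cut the same chain one bond further out and gave a modest gain beyond the scatter. Among the compounds with values here, compound 4 adds one more carbon to that chain, so a further gain of similar or smaller size is expected in this assay, but with only one step to go on it could also fall within the scatter.

For compound 4 the expected value in this assay is 0.02 mg/kg, range 0.008 mg/kg to 0.05 mg/kg, i.e. a step of a 1.5-fold lower number from compound 3 to compound 4 (0.18 log units; within the scatter) is expected.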

Compound 4, dose for 50% inhibition: 0.1 mg/kg
Compound 4: the middle estimate sits 5.0-fold (0.70 log units) below what was measured; measured number outside the range, above it.
By their numbers in this assay, from the lowest: compound 3; then compounds 2 and 4 (each within the scatter of the next); then compound 1.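

Lengthening the chain once more gives a 3.3-fold higher number from compound 3 to compound 4 (0.52 log units; beyond the scatter) in this assay, the opposite direction to a 3.3-fold lower number from compound 2 to compound 3 (0.52 log units; beyond the scatter), so chain extension at this position does not keep lowering the number. The gain is lost altogether, with no change at the digits printed from compound 2 to compound 4 (within the scatter), while 3-amino-4-hydroxy-3-(hydroxymethyl)butyl in place of 1-amino-2-hydroxy-1-(hydroxymethyl)ethyl on an aromatic carbon gives a 3.0-fold lower number from compound 1 to compound 4 (0.48 log units; beyond the scatter). Nothing available accounts for this reversal.

Open, on these data alone, is where an octyl chain would fall relative to compound 3, and whether a dodecyl chain would raise the number further than compound 4 does. For the compounds shown here, the turn at compound 3 rests on only one step on each side.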